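The source may report more compounds than this note shows. Statements on the series, on what has been measured and on what is new or still open speak of the compounds shown alone.

Of the compounds shown here, three built on one shared core have been tested in a functional assay on HCT-116 cells (Homo sapiens) for cytotoxicity, read by MTT assay, with a stated time of 72 h; on this read-out lower numbers stand for stronger inhibition and higher numbers for weaker inhibition. Compound 1 `COc1cc2nc(Cc3ccccc3Cl)[nH]c(=O)c2cc1OC` gives 9000 nM, compound 2 `COc1cc2nc(Cc3cccc4ccccc34)[nH]c(=O)c2cc1OC` gives 1700 nM, and compound 3 `COc1cc2nc(-c3ccccc3Cl)nc(N=[N+]=[N-])c2cc1OC` gives 8000 nM. Compound 3 therefore holds the second highest of the three numbers: compound 1 is its nearest neighbour, a gap within the usual scatter, while compound 2 lies furthest away, a gap beyond it. Compound 4 `COc1cc2nc(-c3cccc(C)c3)nc(N=[N+]=[N-])c2cc1OC` has not yet been measured. It differs from compound 3 in one place: 3-methylphenyl in place of 2-chlorophenyl on an aromatic carbon. For the measured compounds named here, no pair of measured compounds shows this change by itself, so its size cannot be read from the data. The step of a 1.1-fold lower number from compound 3 to compound 4 (0.06 log units; within the scatter) is expected to stay not clearly beyond the scatter in either direction. The estimate for compound 4 is 7000 nM, with a range from 2500 nM to 20000 nM.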

Compound 4, half-maximal inhibitory concentration: 9000 nM
For compound 4 the middle estimate is 1.3-fold (0.11 log units) below the measured one; the range from low to high includes it.
By their numbers in this assay, from the lowest: compound 2; then compounds 3, 1 and 4 (each within the scatter of the next).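

In this assay, putting 3-methylphenyl in place of 2-chlorophenyl on the aromatic carbon between two ring nitrogen atoms gives a 1.1-fold higher number from compound 3 to compound 4 (0.05 log units; within the scatter) and so leaves the two compounds indistinguishable. This single swap alters both the group on the phenyl ring and where it sits, so it cannot show what each alteration does alone. Nothing at hand explains why the two compounds read alike. Going by these compounds, whether an amine or a carboxylic acid on this phenyl ring would give a different number remains open. So does the effect of replacing the phenyl ring with a longer chain.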